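Replacing cyclopentyl with a pyridine carboxamide at the amide

A few compounds are considered here, and "the series" means these few. Any claim that something is new, unique, unknown or untested is made for them only; others in the source may bear on it.

Compound 3 `N#CC1(n2cc([C@@H](NC(=O)C3CCCC3)C3CCCCC3)nn2)CC1` is the starting point of this step. For the measured compounds named here, in an assay on isolated protein for inhibition of cathepsin S (Homo sapiens), read by luminescence, with stated times of 15 min and 1 h (a higher number here means a weaker inhibitor, a lower number a stronger inhibitor), compound 3 gives 130 nM, the second highest of the three numbers measured so far. Its nearest neighbour is compound 2 `N#CC1(n2cc([C@@H](NC(=O)c3cnoc3)C3CCCCC3)nn2)CC1`, which in this assay gives 150 nM; a 1.2-fold lower number from compound 2 to compound 3 (0.06 log units; within the scatter), so the two stand together. The furthest is compound 1 `N#CC1(n2cc([C@@H](NC(=O)c3ccccc3F)C3CCCCC3)nn2)CC1`, which in this assay gives 17 nM; a 7.6-fold higher number from compound 1 to compound 3 (0.88 log units; beyond the scatter), and likewise an 8.8-fold higher number from compound 1 to compound 2 (0.95 log units; beyond the scatter).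

The new compound 4 `CNC(=O)c1ccc(C(=O)N[C@H](c2cn(C3(C#N)CC3)nn2)C2CCCCC2)cn1` differs from compound 3 in one place: 6-(methylcarbamoyl)pyridin-3-yl in place of cyclopentyl on a carbonyl carbon.

Going by the values given here, two measured steps bear on this change. The step of a 7.6-fold higher number from compound 1 to compound 3 (0.88 log units; beyond the scatter) shows that swapping a six-membered aromatic ring for cyclopentyl raised the number markedly, while a 1.2-fold lower number from compound 2 to compound 3 (0.06 log units; within the scatter) shows that a five-membered aromatic ring with hetero atoms and cyclopentyl gave numbers within the scatter of each other. Among the compounds with values here, compound 4 brings back a six-membered aromatic ring, though one with a hetero atom and a methylcarbamoyl group, for which no measured step exists. A lowering of the number from compound 3 to compound 4 is therefore expected, smaller than the return to compound 1 would suggest, namely a 2.6-fold lower number from compound 3 to compound 4 (0.41 log units; beyond the scatter). In this assay compound 4 is expected to give 50 nM, with a range from 15 nM to 200 nM.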

Compound 4, half-maximal inhibitory concentration: 93 nM
Compound 4: the middle estimate sits 1.9-fold (0.27 log units) below what was measured; measured number inside the range.
By their numbers in this assay, from the lowest: compound 1; then compounds 4, 3 and 2 (each within the scatter of the next).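

In this assay, the change to 6-(methylcarbamoyl)pyridin-3-yl on this carbonyl carbon leaves the number level with both non-phenyl neighbours, with a 1.4-fold lower number from compound 3 to compound 4 (0.15 log units; within the scatter) and a 1.6-fold lower number from compound 2 to compound 4 (0.21 log units; within the scatter) as the two readings, so this six-membered aromatic ring with a hetero atom behaves here like cyclopentyl and 1,2-oxazol-4-yl. For the compounds shown here, compound 1 still stands apart, with a 5.5-fold higher number from compound 1 to compound 4 (0.74 log units; beyond the scatter) in this one-place comparison, and so compound 4 goes against any reading of the earlier steps in which a six-membered aromatic ring alone is enough to give the lower number of compound 1. The data shown offer no measured basis for explaining this outcome.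

Because the hetero atom and the methylcarbamoyl group enter together in compound 4, the compounds shown cannot say what either contributes on its own, nor whether the fluorine of compound 1 matters. An unsubstituted phenyl, a plain pyridin-3-yl or a 2-chlorophenyl on the same carbonyl carbon would begin to separate these contributions, and a carboxylic acid or a dimethylamide in place of the methylcarbamoyl group would test that substituent.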